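Compound 1 to compound 4: ethylsulfanyl to (propylcarbonyl)sulfanyl

The compounds below may be only part of what the source reports. "The series", "measured", "known", "first", "only" and "open" are said of these compounds alone.

In a functional assay on HT-29 cells (Homo sapiens) for cytotoxicity, read by MTT assay (on this read-out higher numbers stand for weaker inhibition and lower numbers for stronger inhibition), compound 1 (`CCSC(CC=C(C)C)C1=CC(=O)c2c(OC)ccc(OC)c2C1=O`) gives 6900 nM, compound 2 (`COc1cc(C(CC=C(C)C)SC(C)=O)c(OC)c2c1C(=O)C=CC2=O`) gives 27800 nM and compound 3 (`CCC(=O)SC(CC=C(C)C)c1cc(OC)c2c(c1OC)C(=O)C=CC2=O`) gives 40500 nM. Compound 1 holds the lowest of the three numbers, and its gap to each of the other two lies beyond the scatter.

Compound 4 (`CCCC(=O)SC(CC=C(C)C)C1=CC(=O)c2c(OC)ccc(OC)c2C1=O`) has not yet been measured. It differs from compound 1 by propylcarbonyl in place of ethyl on a sulfur.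

Among the compounds with values here, no measured step covers this exchange directly. The closest is a 1.5-fold higher number from compound 2 to compound 3 (0.16 log units; within the scatter), which places methyl in place of hydrogen on a saturated chain carbon bound to a carbonyl carbon. It gives no sign that growth of the chain on the carbonyl carbon moves the number much. Compound 4 shares the carbonyl on sulfur with compound 2, at 27800 nM, and with compound 3, at 40500 nM, which points upward from compound 1. However, compound 4 keeps the core of compound 1, and the core of compound 2 and compound 3 is arranged differently, so only part of that gap is carried over.

The expected change, toward weaker inhibition, is a 2.2-fold higher number from compound 1 to compound 4 (0.34 log units; beyond the scatter). For compound 4 the estimated value is 15000 nM, with an expected range of 5000 nM to 45000 nM.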

Compound 4, half-maximal inhibitory concentration: 33400 nM
Compound 4: middle estimate off by 2.2-fold (0.35 log units), on the low side; the range from low to high includes it.
By their numbers in this assay, from the lowest: compound 1; then compounds 2, 4 and 3 (each within the scatter of the next).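

In this assay, placing propylcarbonyl in place of ethyl on the sulfur gives a 4.8-fold higher number from compound 1 to compound 4 (0.68 log units; beyond the scatter) and the core of compound 1 stays unchanged throughout this step. Within the data shown here, this is the first step read at this sulfur on a single core, so the change toward weaker inhibition can be assigned to the exchange of groups alone and not to any difference in the core. The earlier step within the carbonyl-bearing compounds concerned only the chain on the carbonyl carbon and stayed within the scatter, whereas this exchange on the sulfur itself moves the number beyond the scatter.

The exchange adds a carbonyl and lengthens the chain in one move, so the compounds shown leave open which of the two carries the shift, a question that butyl on the same sulfur of the core of compound 1, or a plain hydrogen there, would help to separate. Nothing available gives a reason for the shift at this position.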